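Cyclohexylamino in Place of Piperidin-1-yl on a Sulfonyl Sulfur

The source may hold more compounds than are shown below. What is called first, only, known or untested is meant among the compounds shown, and "the series" means these compounds.

Compound 1 `CN(C)S(=O)(=O)c1cc(C(=O)O)ccc1NCCCC(F)(F)F`: > 1 h
Compound 2 `O=C(O)c1ccc(NCCCCCCCC(F)(F)F)c(S(=O)(=O)N2CCCCC2)c1`: > 1 h

In an ADME assay on microsomes from liver (Mus musculus) for metabolic stability, tested at 5 uM (a lower number here means that the compound disappears faster, a higher number that the compound lasts longer), compound 1 gives > 1 h, which is a limit of the assay rather than a number. Compound 2 gives > 1 h in this assay, again a limit. Within the data shown here, both therefore rest at the limit of > 1 h in this assay, at which 2 of the 2 values shown sit, so no step between measured compounds can be sized here.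

Compound 3 `O=C(O)c1ccc(NCCCCCCCC(F)(F)F)c(S(=O)(=O)NC2CCCCC2)c1` is the unmeasured neighbour of compound 2. The change is cyclohexylamino in place of piperidin-1-yl on a sulfonyl sulfur. With both known values sitting at the same limit, no step beyond the usual scatter is expected; the estimated change a step that the limit leaves unreadable from compound 2 to compound 3 reflects that. Compound 3 is thus expected to reach about 1.5 h, within 0.7 h to 3 h, most likely again reported only as a limit.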

Compound 3, half-life: > 1 h
Compound 3: no number, only a limit; the forecaster's own chance of this, stated with the estimate: 70%; the middle value lies beyond the limit too.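

In this assay no step can be read between compound 2 and compound 3, as both rest at a limit: the limit of > 1 h in this assay, at which 3 of the 3 values shown sit.

Going by these compounds, how long each compound actually lasts, and whether cyclohexylamino in place of piperidin-1-yl makes any difference, stays open.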